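A few compounds are considered here, and "the series" means these few. Any claim that something is new, unique, unknown or untested is made for them only; others in the source may bear on it.

Measured so far in a functional assay on CUTLL1 cells (Homo sapiens) for inhibition, read by resazurin assay, with a stated time of 48 h, in the presence of a further agent that is not named here; on this read-out lower numbers stand for an effect already at smaller amounts and higher numbers for an effect only at larger amounts of compound:

Compound 1 `Nc1ncc(-c2ccccn2)c(C2CC2)n1`: > 100000 nM (a limit)
Compound 2 `Nc1ncc(-c2ccccc2)c(C2CC2)n1`: > 100000 nM (a limit)
Compound 3 `CC(C)c1nc(N)ncc1-c1ccncc1`: > 100000 nM (a limit)

Compound 3 has no numerical value in this assay. Its entry of > 100000 nM is a limit of the assay. Compound 1 and compound 2 also have only limits, so all three measured compounds stand at the same mark: the limit of > 100000 nM in this assay, at which 3 of the 3 values shown sit. Among the measured compounds shown here, no two of them differ in one place, so no measured step is available as a guide.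

Compound 4 `Nc1ncc(-c2ccncc2)c(C2CCC2)n1` carries cyclobutyl in place of isopropyl on an aromatic carbon, next to the ring nitrogen: cyclobutyl in place of isopropyl on an aromatic carbon. No step beyond the scatter is expected in this assay, and compound 4 may well return only a limit too. This expectation rests on compound 3, whose > 100000 nM is a limit. The expected a number no higher from compound 3 to compound 4 (the limit leaves the size open) is no larger than the scatter. Compound 4 is estimated at 100000 nM, with an expected range from 30000 nM to 200000 nM.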

Compound 4, half-maximal effective concentration: > 100000 nM
Compound 4 was reported as a limit; the forecaster's own chance of this, stated with the estimate: 75%; the middle value sits exactly at the limit.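

Compound 3 and compound 4 are both reported only as limits, so no step can be read for cyclobutyl in place of isopropyl. All the compounds shown stand at one mark: the limit of > 100000 nM in this assay, at which 4 of the 4 values shown sit. They leave open whether any change to the shared core gives a numerical value in this assay at all.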